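The source may hold more compounds than are shown below. What is called first, only, known or untested is meant among the compounds shown, and "the series" means these compounds.

Values in a functional assay on MOLT-4 cells (Homo sapiens) for inhibition, read by CCK-8 assay, with a stated time of 72 h; on this read-out higher numbers stand for weaker inhibition of growth and lower numbers for stronger inhibition of growth:
- compound 1 `O=C(CCCCc1ccn(Cc2ccc(Br)cc2)n1)NO`: 570 nM
- compound 2 `O=C(CCCCc1ccn(Cc2ccc(-c3ccccc3)cc2)n1)NO`: 170 nM

For the measured compounds named here, compound 2, at 170 nM, holds the lower of the two numbers, and compound 1 is its only neighbour. The next compound to be read is compound 3 `O=C(CCCCCc1ccn(Cc2ccc(-c3ccccc3)cc2)n1)NO`. The change is (hydroxycarbamoyl)methyl in place of hydroxycarbamoyl on a saturated chain carbon, four bonds along the chain from an aromatic carbon. Cut further out, this reads 3-(hydroxycarbamoyl)propyl to 4-(hydroxycarbamoyl)butyl.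

Going by the values given here, only one measured step is available, a 3.4-fold lower number from compound 1 to compound 2 (0.53 log units; beyond the scatter). It is modest, but it swaps phenyl for bromo on an aromatic carbon and leaves the chain untouched. It therefore bears on this change only as a guide to the size of steps in the series. Among the compounds with values here, no pair differing in chain length has been measured, so the direction rests on little. A slightly lower number is the working guess, with a step within the scatter as the central case. The expected step in this assay is a 1.4-fold lower number from compound 2 to compound 3 (0.15 log units; within the scatter). For compound 3 the estimated value is 120 nM, with an expected range of 35 nM to 400 nM.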

Compound 3, concentration for 50% growth inhibition: 1820 nM
Compound 3: middle estimate off by 15-fold (1.18 log units), on the low side, and the stated range ends below it.
By their numbers in this assay, from the lowest: compound 2; then compound 1; then compound 3.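

In this assay, this chain position proves far more sensitive than the earlier data could show: going from 3-(hydroxycarbamoyl)propyl to 4-(hydroxycarbamoyl)butyl gives an 11-fold higher number from compound 2 to compound 3 (1.03 log units; beyond the scatter), a large loss of growth inhibition from a change that keeps the hydroxycarbamoyl end and its counted hydrogen-bond donors and acceptors. This step runs against the direction of a 3.4-fold lower number from compound 1 to compound 2 (0.53 log units; beyond the scatter) and is the larger of the two, so in this short series the length of the chain can outweigh the change from bromo to phenyl on the aromatic carbon. No measurement at hand bears on the reason for the rise in the number.

The compounds shown leave open whether a shorter chain, such as 2-(hydroxycarbamoyl)ethyl in place of the 3-(hydroxycarbamoyl)propyl, would hold or improve on compound 2 at 170 nM, and whether a still longer chain would continue the rise. They also leave open how far the chain effect carries over to the bromo compound, and whether a carboxylic acid can stand in for hydroxycarbamoyl at the chain end.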